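The source may report more compounds than this note shows. Statements on the series, on what has been measured and on what is new or still open speak of the compounds shown alone.

Measured so far in an ADME assay on a cell-free system (plasma, Homo sapiens) for protein binding, at pH 7.4:

- compound 1 `CN1CC(c2nc(C(=O)NCc3ccc(F)cc3)c(O)c3ncccc23)CC1=O` gives 98.8%
- compound 2 `CN1CC(c2nc(C(=O)NCc3ccc(F)cc3S(C)(=O)=O)c(O)c3ncccc23)CC1=O` gives 97%
- compound 3 `CN(C)C(=O)CN1CC(c2nc(C(=O)NCc3ccc(F)cc3)c(O)c3ncccc23)CC1=O` gives 94.8%

Of these three, compound 1 has the lowest unbound fraction, with compound 2 its nearest neighbour and compound 3 the furthest away. The next compound, compound 4 `O=C(NCc1ccc(F)cc1)c1ncc2cccnc2c1O`, has hydrogen in place of 1-methyl-5-oxopyrrolidin-3-yl on an aromatic carbon. Two measured steps offer some guidance, a 2.5-fold higher unbound fraction from compound 1 to compound 2 (0.40 log units; beyond the scatter) and a 4.3-fold higher unbound fraction from compound 1 to compound 3 (0.64 log units; beyond the scatter). Both add a group to compound 1, and the second does so on the very group that compound 4 lacks. Among the measured compounds shown here, neither removes that group, so the data hold no direct precedent for this change. Both steps are modest and raise the unbound fraction, which suggests at most a small shift towards more free compound in this assay, and none beyond the scatter is expected. The expected change is a 1.7-fold higher unbound fraction from compound 1 to compound 4 (0.22 log units; within the scatter). For compound 4 the estimated value is 98%, with an expected range from 94.5% to 99.4%.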

Compound 4, plasma protein binding: 99.2%
Compound 4: middle estimate off by 2.5-fold (0.40 log units) (unbound fraction), on the high side, and the stated range covers the measured number.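

Replacing the 1-methyl-5-oxopyrrolidin-3-yl on this aromatic carbon with hydrogen gives a 1.5-fold lower unbound fraction from compound 1 to compound 4 (0.18 log units; within the scatter) in this assay, so the whole group can go without a shift beyond the scatter. The earlier compounds shown here showed only additions to compound 1, including dimethylcarbamoyl on this same group, which gave a 4.3-fold higher unbound fraction from compound 1 to compound 3 (0.64 log units; beyond the scatter) in that series; compound 4 shows that the high binding does not depend on the 1-methyl-5-oxopyrrolidin-3-yl being present. Nothing available here explains this result.

On these data alone, whether an amine or a carboxylic acid on this aromatic carbon would move the unbound fraction beyond the scatter remains open. So does whether methylsulfonyl would have the same effect on compound 4 as it has on compound 1.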